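Swapping Chloro for Fluoro on Two Fused Cores

The compounds below may be only part of what the source reports. "The series", "measured", "known", "first", "only" and "open" are said of these compounds alone.

Three compounds share a bromo-bearing fused core and differ in what sits on the remaining aromatic positions. Compound 1 `Fc1ccc(Cn2nnc3c(Br)cccc32)cc1` and compound 2 `Clc1ccc(Cn2nnc3c(Br)cccc32)cc1` differ in one place only. In an ADME assay on microsomes from liver (Homo sapiens) for metabolic stability, tested at 2.5 uM (a lower number here means slower removal, a higher number faster removal of the compound), compound 1 gives 1.2 mL/min/g, and compound 2 gives 0.6 mL/min/g. The change between them is fluoro in place of chloro on an aromatic carbon. Compound 3 `Clc1cc(Br)c2nnn(CC3CC3)c2c1` carries a different core; the difference between the two cores is not broken down here. In this assay compound 3 gives 0.5 mL/min/g. Compound 4 `Fc1cc(Br)c2nnn(CC3CC3)c2c1` has not yet been measured; it differs from compound 3 by fluoro in place of chloro on an aromatic carbon. This is the same kind of change as from compound 2 to compound 1, but the surroundings differ: in compound 3 the carbon lies in a six-membered aromatic ring of carbon only that is part of a fused or bridged system of two rings, meta to a bromo group, meta to a fused ring and para to a fused ring, whereas in compound 2 it is para to a large group. Because the earlier step of a 2.0-fold higher number from compound 2 to compound 1 (0.30 log units; within the scatter) stayed within the scatter, a similar step a 1.6-fold higher number from compound 3 to compound 4 (0.20 log units; within the scatter) is expected. For compound 4 the estimate in this assay is 0.8 mL/min/g, most likely between 0.4 mL/min/g and 1.6 mL/min/g.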

Compound 4, intrinsic clearance in a liver preparation (reported as CLH), per the amount of preparation that the assay uses: 0.4 mL/min/g
Beside the measured number, compound 4's estimate is 2.0-fold (0.30 log units) above it; low and high end bracket the measured number.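

In this assay, putting fluoro in place of chloro on the core of compound 3 gives a 1.3-fold lower number from compound 3 to compound 4 (0.10 log units; within the scatter), so on this core the swap produces no change that can be told apart from the ordinary spread of repeat measurements. The two steps point in opposite directions on paper, yet this does not count as a real difference between the cores: the same change on two cores in this assay, a 2.0-fold higher number (0.30 log units; within the scatter) from compound 2 to compound 1 and a 1.3-fold lower number (0.10 log units; within the scatter) from compound 3 to compound 4, 2.5-fold (0.40 log units) apart, within the scatter of two such steps. The data therefore fit a swap that carries across these two cores with little effect, but two pairs, each within the scatter, cannot prove that, nor can they show what the swap would do on a core where it had a clear effect.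

The compounds shown carry only chloro or fluoro at this aromatic carbon, so how the number would respond to a nitrile, a methoxy group or an amine there stays open. A carboxylic acid or a longer chain at the same carbon is equally unexplored here.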